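The source may hold more compounds than are shown below. What is called first, only, known or untested is meant among the compounds shown, and "the series" means these compounds.

Measured so far:
- compound 1 `Cc1cccc(N(C)S(=O)(=O)C2CC3OC2C(c2ccc(NC(=O)CCCCCCC(=O)O)cc2)=C3c2ccc(O)cc2)c1` — in a functional assay on DU-145 cells (Homo sapiens) for antiproliferative activity, read by MTT assay, with a stated time of 72 h (a higher number here means a weaker inhibitor, a lower number a stronger inhibitor), compound 1 gives > 100000 nM
- compound 2 `CCN(c1ccc(OC)cc1)S(=O)(=O)C1CC2OC1C(c1ccc(NC(=O)CCCCCCC(=O)O)cc1)=C2c1ccc(O)cc1` — compound 2 gives 24400 nM
- compound 3 `CCN(c1cccc(OC)c1)S(=O)(=O)C1CC2OC1C(c1ccc(NC(=O)CCCCCCC(=O)O)cc1)=C2c1ccc(O)cc1` — compound 3 gives 71100 nM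

Compound 1 is known only as a limit. The value of compound 1 is the assay's limit, not a number, so its standing among the three rests on the limit of > 100000 nM in this assay, at which 1 of the 3 values shown sits, alone: compound 2 and compound 3 both give numbers, and compound 1 sits at or beyond the weak end of the set.

Compound 4 `CCN(c1ccc(O)cc1)S(=O)(=O)C1CC2OC1C(c1ccc(NC(=O)CCCCCCC(=O)O)cc1)=C2c1ccc(O)cc1` differs from compound 1 by ethyl(4-hydroxyphenyl)amino in place of methyl(3-methylphenyl)amino on a sulfonyl sulfur. Two measured steps leave compound 1 by a closely related change: an at least 4.0-fold lower number from compound 1 to compound 2 (0.61 log units; beyond the scatter) and an at least 1.4-fold lower number from compound 1 to compound 3 (0.14 log units; that floor lies within the scatter). The entering group of compound 2 differs from that of compound 4 only in methoxy against hydroxy, so the step to compound 2 is the nearer guide; a 2.9-fold higher number from compound 2 to compound 3 (0.46 log units; beyond the scatter) shows that the pattern of substitution on the phenyl also matters within this pair. The step to compound 4 is therefore expected to run in the same direction as the step to compound 2, and of comparable size, though the floor set by the limit of compound 1 leaves its true size open.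

Compound 4 is estimated at 25000 nM, with a range of 8000 nM to 80000 nM. This estimate means an at least 4.0-fold lower number from compound 1 to compound 4 (0.60 log units; beyond the scatter).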

Compound 4, half-maximal inhibitory concentration: > 100000 nM
Compound 4 gave a limit, no number (the forecaster's own chance of this, stated with the estimate: 20%); middle value at least 4.0-fold (0.60 log units) from the limit.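

In this assay compound 4 gives > 100000 nM as a limit and not a number, a reading it shares with compound 1: the limit of > 100000 nM in this assay, at which 2 of the 4 values shown sit.

On the sulfonamide nitrogen, the free hydroxy is not interchangeable with the methoxy: hydrogen in place of methyl on an oxygen on an aromatic ring gives an at least 4.0-fold higher number from compound 2 to compound 4 (0.61 log units; beyond the scatter) and this one small change is enough to lose the measurable activity of compound 2. Against the other methoxy compound, 4-hydroxyphenyl in place of 3-methoxyphenyl gives an at least 1.4-fold higher number from compound 3 to compound 4 (0.14 log units; that floor lies within the scatter) and that floor settles no order, while the step between compound 1 and compound 4 cannot be read.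

As far as these compounds go, how far compound 4 lies past its limit remains open. Also open, from the compounds shown here alone, is whether an amine on that phenyl, or a propyl chain in place of the ethyl on the sulfonamide nitrogen, would return a measurable number.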